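The source may hold more compounds than are shown below. What is called first, only, known or untested is meant among the compounds shown, and "the series" means these compounds.

Within the data shown here, in a functional assay on the whole organism with Rattus norvegicus as the target (a lower number here means that less compound is needed, a higher number that more compound is needed for the effect), compound 1 (`COc1nc(C)cc(SC)c1NC(=O)N(Cc1ccc(Oc2ccc(F)cc2)cc1)C1CCCCCC1`) gives 1.4 mg/kg and compound 2 (`Cc1cc(S(C)(=O)=O)c(NC(=O)N(Cc2ccc(Oc3ccc(F)cc3)cc2)C2CCCCCC2)c(S(C)(=O)=O)n1`) gives 0.63 mg/kg as the lower of the two numbers so far, with a gap to compound 1 that lies beyond the usual scatter. Among the measured compounds shown here, these two compounds differ in more than one place, so no single-change step is available as a guide. Compound 3 (`Cc1cc(S(C)(=O)=O)c(NC(=O)N(Cc2ccc(Oc3ccc(F)cc3)cc2)C2CCCCCC2)c(Cl)n1`) has not yet been measured. It carries chloro in place of methylsulfonyl on an aromatic carbon relative to compound 2 (chloro in place of methylsulfonyl on an aromatic carbon). Neither measured compound carries chloro, so the only anchor is the span from compound 2 at 0.63 mg/kg to compound 1 at 1.4 mg/kg in this assay for this series. A modest rise in the dose needed is expected, of a size near the edge of the scatter, and no real change would not surprise. The expected step is a 1.4-fold higher number from compound 2 to compound 3 (0.15 log units; within the scatter) and it remains a tentative call. For compound 3 the estimated value is 0.9 mg/kg with an expected range from 0.3 mg/kg to 2.5 mg/kg as the working window.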

Compound 3, dose for half-maximal effect: > 1 mg/kg
Compound 3: only a limit was reported (the forecaster's own chance of this, stated with the estimate: 5%); middle value at least 1.1-fold (0.04 log units) from the limit.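

For compound 3, this assay yields a limit and not a number: the limit of > 1 mg/kg in this assay, at which 1 of the 3 values shown sits.

Among these compounds, replacing methylsulfonyl with chloro on the aromatic carbon next to the ring nitrogen gives an at least 1.5-fold higher number from compound 2 to compound 3 (0.20 log units; that floor lies within the scatter), the first single-change reading at this position, and it leaves no room for a fall in the dose needed. Methylsulfonyl at this carbon therefore cannot be exchanged for chloro with a gain in this readout, although the floor of the step does not by itself establish a real loss, and the step from compound 1 to compound 3 cannot be read.

Still open, going by these compounds, are the actual value of compound 3 and whether its step from compound 2 ends up beyond the scatter. Also open, on these data alone, is how an amine or a nitrile in place of methylsulfonyl on this carbon would read in this assay, and whether the same exchange of methylsulfonyl for chloro would give a comparable step at the other methylsulfonyl group.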